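The step from compound 3 to compound 4

The compounds below may be only part of what the source reports. "The series", "measured", "known", "first", "only" and "open" are said of these compounds alone.

Measured so far in a physicochemical assay for lipophilicity, using the shake flask method; a higher number here means a more lipophilic compound, a lower number a more polar compound
Compound 1 `Cc1ccc(NC(=O)c2cc(Oc3ccc(S(C)(=O)=O)cc3)cc(OC(C)C)c2)nc1` gives 4.05
Compound 2 `CC(C)Oc1cc(Oc2ccc(S(C)(=O)=O)cc2)cc(-c2ccnc(=O)[nH]2)c1` gives "not determined" (no result reported)
Compound 3 `Cc1cc(=O)[nH]c(-c2cc(Oc3ccc(S(C)(=O)=O)cc3)cc(OC(C)C)c2)n1` gives 2.43

Compound 3 holds the lower of the two numbers available, and compound 2 has none. Compound 4 `CCc1cnc(-c2cc(Oc3ccc(S(C)(=O)=O)cc3)cc(OC(C)C)c2)[nH]c1=O` differs from compound 3 by a group of 9 heavy atoms (6 carbon, 2 nitrogen, 1 oxygen; one six-membered aromatic ring with 2 hetero atoms) in place of a group of 8 heavy atoms (5 carbon, 2 nitrogen, 1 oxygen; one six-membered aromatic ring with 2 hetero atoms), on an aromatic carbon and nothing else. Among the compounds with values here, only one measured step bears on this, and only loosely: a number 1.62 log units lower from compound 1 to compound 3 (beyond the scatter) with a smaller group entering. Here the entering group is the larger one and the difference in size is smaller, so a modest step upward is expected in this assay overall. The expected step is a number 0.37 log units higher from compound 3 to compound 4 (beyond the scatter) in this estimate. For compound 4 the estimated value is 2.8 within 2.4 to 3.3 as the likely span.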

Compound 4, distribution coefficient: 3.11
Compound 4: the middle estimate sits 0.31 log units below what was measured; low and high end bracket the measured number.
By their numbers in this assay, from the lowest: compound 3; then compound 4; then compound 1.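

At this aromatic carbon, one ring group can replace another of the same ring type, with the same hydrogen-bond donor and acceptor counts, and this assay still shifts: the change gives a number 0.68 log units higher from compound 3 to compound 4 (beyond the scatter) with the group of 9 heavy atoms entering. That same group gives a number 0.94 log units lower from compound 1 to compound 4 (beyond the scatter) when it replaces the group of 10 heavy atoms, so the ring groups are not interchangeable here. No measurement here explains either shift. Still open, on these data alone, is how a longer chain, an amine or a carboxylic acid on this ring would read.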